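The compounds below may be only part of what the source reports. "The series", "measured", "known", "first", "only" and "open" are said of these compounds alone.

Three compounds share one core. In a functional assay on Ehrlich cells (Mus musculus) for cytotoxicity, read by trypan blue exclusion, with a stated time of 2 h, tested at 10 ug/mL (on this read-out lower numbers stand for a weaker effect and higher numbers for a stronger effect at the one concentration tested), compound 1 `COc1ccccc1C1C(C#N)=C(N)N(c2ccc(S(N)(=O)=O)cc2)C2=C1CCCC2` gives 30%, compound 2 `COc1ccc(C2C(C#N)=C(N)N(c3ccc(S(N)(=O)=O)cc3)C3=C2CCCC3)cc1` gives 50%, and compound 3 `N#CC1=C(N)N(c2ccc(S(N)(=O)=O)cc2)C2=C(CCCC2)C1c1ccc([N+](=O)[O-])cc1` gives 0%, the lowest of the three numbers, below both others by more than the scatter. The steps of a number 30 percentage points lower from compound 1 to compound 3 (beyond the scatter) and a number 50 percentage points lower from compound 2 to compound 3 (beyond the scatter) both bear on what follows. Compound 4 `N#CC1=C(N)N(c2ccc(S(N)(=O)=O)cc2)C2=C(CCCC2)C1c1ccc(Cl)cc1Cl` differs from compound 3 in one place: 2,4-dichlorophenyl in place of 4-nitrophenyl on a saturated ring carbon. Since compound 3 lost ground when nitro entered, as seen in a number 50 percentage points lower from compound 2 to compound 3 (beyond the scatter), removing the nitro group is expected to give back some of that loss; compound 4 is therefore expected to rise by a number 35 percentage points higher from compound 3 to compound 4 (beyond the scatter) in this assay. The estimate for compound 4 is 35%, ranging from 5% to 65%.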

Compound 4, a percentage reported as activity, at one concentration (the size of the read-out at that concentration, not a potency): 0%
Estimate against measurement, compound 4: 35 percentage points above; the measured number lies below the stated range.
By their numbers in this assay, from the lowest: compounds 3 and 4 (each within the scatter of the next); then compound 1; then compound 2.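

In this assay, the loss of the nitro group alone did not restore the effect: 2,4-dichlorophenyl in place of 4-nitrophenyl on the saturated ring carbon gave (no change at the digits printed from compound 3 to compound 4 (within the scatter)). The nitro group is thus not the only substituent here that goes with no effect at the concentration tested, as the methoxyphenyl compounds also stand apart from the dichlorophenyl one (a number 50 percentage points lower from compound 2 to compound 4 (beyond the scatter); a number 30 percentage points lower from compound 1 to compound 4 (beyond the scatter)). Nothing available explains this result. Still open, going by these compounds, is whether a phenyl ring bearing one chlorine, a hydroxyl group or an amine would retain the effect.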